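Working notes: 4-methylpiperidin-1-yl in place of methoxy

The source may hold more compounds than are shown below. What is called first, only, known or untested is meant among the compounds shown, and "the series" means these compounds.

Three compounds carry numbers in a functional assay for inhibition, with Homo sapiens as the target; a lower number here means a stronger inhibitor, a higher number a weaker inhibitor. Compound 1 `CC1CCN(c2ccc(Nc3nccc(-c4cccnc4)n3)cc2)CC1` gives 500 nM. Compound 2 `COc1ccc(Nc2nccc(-c3cccs3)n2)cc1` gives 3900 nM, the second highest of the three numbers; its nearest neighbour is compound 3 `Fc1cccc(F)c1Nc1nccc(-c2cccnc2)n1`, which gives 21000 nM, and its furthest is compound 1. Compound 4 `CC1CCN(c2ccc(Nc3nccc(-c4cccs4)n3)cc2)CC1` has not yet been measured. It differs from compound 2 in one place: 4-methylpiperidin-1-yl in place of methoxy on an aromatic carbon. Within the data shown here, no step between measured compounds covers this change, so its size can only be expected. Because compound 1, which carries the same 4-methylpiperidin-1-yl, gives 500 nM, a move to a lower number beyond the scatter is expected in this assay, estimated as a 5.6-fold lower number from compound 2 to compound 4 (0.75 log units; beyond the scatter). Compound 4 is expected to give 700 nM, with a range of 200 nM to 2500 nM.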

Compound 4, half-maximal inhibitory concentration: 400 nM
For compound 4 the middle estimate is 1.8-fold (0.24 log units) above the measured one, within the range that was stated.
By their numbers in this assay, from the lowest: compounds 4 and 1 (each within the scatter of the next); then compound 2; then compound 3.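

In this assay, 4-methylpiperidin-1-yl in place of methoxy on an aromatic carbon para to a large group gives a 9.8-fold lower number from compound 2 to compound 4 (0.99 log units; beyond the scatter) and so puts a direct size on this change. With 4-methylpiperidin-1-yl held constant, thiophen-2-yl in place of pyridin-3-yl gives a 1.3-fold lower number from compound 1 to compound 4 (0.10 log units; within the scatter) and does not separate these two rings. No available evidence bears on the size of the first step.

Open, going by these compounds, is whether a simple amine such as dimethylamino or a carboxylic acid at this position would read like methoxy or like 4-methylpiperidin-1-yl. Also open, on these data alone, is whether the two rings would still match with methoxy in place.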